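Methylsulfanyl for phenoxy in a tolan amide series

A few compounds are considered here, and "the series" means these few. Any claim that something is new, unique, unknown or untested is made for them only; others in the source may bear on it.

Measured so far in a functional assay on TREX cells for negative allosteric modulation of metabotropic glutamate receptor 3 (Rattus norvegicus), read by calcium flux, with a stated time of 2.5 min; on this read-out lower numbers stand for stronger inhibition and higher numbers for weaker inhibition:

Compound 1 `COc1ccc(C#Cc2ccc(C(=O)N3CCC[C@@H](CO)C3)cc2)c(F)c1` gives > 10000 nM, a limit of the assay and not a number.
Compound 2 `O=C(c1ccc(C#Cc2ccc(Oc3ccccc3)cc2)cc1)N1CCC[C@@H](CO)C1` gives > 10000 nM, likewise a limit.
Compound 3 `COc1ccc(C#Cc2ccc(C(=O)N3CC[C@@H](O)C3)cc2)cc1` gives 10200 nM.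

Compound 2 therefore stands at the upper edge of what is recorded here: it is one of the two compounds that sit at the limit, (the limit of > 10000 nM in this assay, at which 2 of the 3 values shown sit), and only compound 3 returns a number, which itself lies close to that limit. Among the measured compounds shown here, the three measured compounds thus show weak inhibition throughout, with no measured step between any pair that differ in one place.

Compound 4 `CSc1ccc(C#Cc2ccc(C(=O)N3CCC[C@@H](CO)C3)cc2)cc1` differs from compound 2 by a single change, (methylsulfanyl in place of phenoxy on an aromatic carbon), that is, methylsulfanyl in place of phenoxy on an aromatic carbon. For the measured compounds named here, nothing among the measured compounds isolates this exchange, and the nearest neighbours (compound 1 and compound 3, each carrying a small ether at the same ring) give weak values as well.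

Going by the values given here, with no measured step to rest on, the expected step from compound 2 to compound 4, a number no higher from compound 2 to compound 4 (the limit leaves the size open), is taken as none beyond the scatter. Compound 4 is accordingly estimated at 10000 nM in this assay, with a range of 4000 nM to 25000 nM, and a fair chance that only a limit is reported.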

Compound 4, half-maximal inhibitory concentration: > 10000 nM
Compound 4: a limit, no number (the forecaster's own chance of this, stated with the estimate: 50%); the middle value lies on the limit itself.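

In this assay compound 4 gives > 10000 nM as a limit of the assay and not a number. Compound 1 and compound 2 also stand at a limit, so neither step to compound 4 can be read: the limit of > 10000 nM in this assay, at which 3 of the 4 values shown sit. On these data alone, whether methylsulfanyl in place of phenoxy changes inhibition at all remains open.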